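Adding an Isopropyl Group on a Second Aryl Ring

The source may hold more compounds than are shown below. What is called first, only, known or untested is meant among the compounds shown, and "the series" means these compounds.

Compound 1 `Cc1ccc(-c2csc(NC(=O)COc3ccccc3)n2)cc1` and compound 2 `Cc1ccc(-c2csc(NC(=O)COc3ccccc3C(C)C)n2)cc1` share one core, while compound 3 `CC(C)c1ccccc1OCC(=O)Nc1nc(-c2ccc(Cl)cc2)cs1` and compound 4 `CC(C)c1ccc(OCC(=O)Nc2nc(-c3ccc(Cl)cc3)cs2)c(C(C)C)c1` share another; the difference between the two cores is not broken down here. In a functional assay on A549 cells (Homo sapiens) for cytotoxicity, read by MTT assay, with a stated time of 48 h (a lower number here means a stronger inhibitor, a higher number a weaker inhibitor), compound 1 gives 41700 nM, compound 2 gives 44200 nM and compound 3 gives 17800 nM. The change from compound 1 to compound 2 is isopropyl in place of hydrogen on an aromatic carbon and produced a 1.1-fold higher number from compound 1 to compound 2 (0.03 log units; within the scatter). The step of a 2.5-fold lower number from compound 2 to compound 3 (0.40 log units; beyond the scatter) is modest. Compound 4 carries the same kind of change, (isopropyl in place of hydrogen on an aromatic carbon), but here the entering group sits meta to an isopropyl group and para to a large group rather than ortho to a large group. Because the earlier step of a 1.1-fold higher number from compound 1 to compound 2 (0.03 log units; within the scatter) stayed within the scatter, a step of about a 1.1-fold higher number from compound 3 to compound 4 (0.03 log units; within the scatter) is expected. Compound 4 is estimated at 19000 nM, with a likely range from 8000 nM to 45000 nM.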

Compound 4, half-maximal inhibitory concentration: 48800 nM
Estimate against measurement, compound 4: 2.6-fold (0.41 log units) below; measured number outside the range, above it.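

In this assay, the entering isopropyl group gives a 2.7-fold higher number from compound 3 to compound 4 (0.44 log units; beyond the scatter), a step beyond the scatter, whereas the same change left compound 1 and compound 2 within the scatter of each other. Even so, the two steps cannot be told apart: the same change on two cores in this assay, a 1.1-fold higher number (0.03 log units; within the scatter) from compound 1 to compound 2 and a 2.7-fold higher number (0.44 log units; beyond the scatter) from compound 3 to compound 4, 2.6-fold (0.41 log units) apart, within the scatter of two such steps. This shows no clear difference between the two cores, but it does not show that the change carries over unaltered, and two pairs give no rule for the series.

From the compounds shown here alone, it remains open whether the core or the place of the entering group sets the size of the step. Going by these compounds, it is also open how a methoxy group or an amine would behave where the second isopropyl group sits in compound 4.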